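Compound 3 to compound 4: cyclohexyl for pyridin-2-yl

The source may hold more compounds than are shown below. What is called first, only, known or untested is meant among the compounds shown, and "the series" means these compounds.

Of the compounds shown here, three have been read in a toxicity assay on HepG2 cells (Homo sapiens) for inhibition, read by resazurin assay, with a stated time of 24 h (a lower number here means that less compound is tolerated, a higher number that more compound is tolerated), so far. Compound 1 `Cn1c([N+](=O)[O-])cnc1C(=O)NC1CC1` gives > 100000 nM as a limit of the assay, not a number. Compound 2 `O=C(NCc1ccc(F)cc1)c1ncc([N+](=O)[O-])[nH]1` gives > 100000 nM as a limit too. Compound 3 `NC(=O)c1nc([N+](=O)[O-])cn1Cc1ccccn1` gives > 100000 nM as a limit as well. Compound 3 therefore has no number, and its place is simply the limit of > 100000 nM in this assay, at which 3 of the 3 values shown sit, for now.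

Compound 4 `NC(=O)c1nc([N+](=O)[O-])cn1CC1CCCCC1` carries cyclohexyl in place of pyridin-2-yl on a saturated chain carbon bound to an aromatic nitrogen, counted as cyclohexyl in place of pyridin-2-yl on a saturated chain carbon bound to an aromatic nitrogen in this change. Among the compounds with values here, the series offers no measured step to scale it against. In this assay no step beyond the usual scatter is expected, and any shift could only be seen as a move down from the limit. That expectation rests on compound 3 with > 100000 nM as its limit. The expected size is a number no higher from compound 3 to compound 4 (the limit leaves the size open) on this estimate. Compound 4 is estimated at 100000 nM with an expected range of 30000 nM to 150000 nM in this reading.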

Compound 4, half-maximal cytotoxic concentration: > 100000 nM
Compound 4: no number, only a limit (the forecaster's own chance of this, stated with the estimate: 75%); the middle value lies on the limit itself.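

Within the data shown here, compound 3 and compound 4 both give only a limit in this assay, and no step between them can be read. The compounds shown leave open whether any change to the shared core would give a measurable number, as the series stands at one value: the limit of > 100000 nM in this assay, at which 4 of the 4 values shown sit.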